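Extending the side chain on compound 1: from cyano to a longer group

The source may report more compounds than this note shows. Statements on the series, on what has been measured and on what is new or still open speak of the compounds shown alone.

Compound 1 `N#CCCn1nc(-c2ccccc2)ccc1=O`: 10.1%
Compound 2 `N=C(S)CCn1[nH]c(=O)ccc1=O`: -13.4%

Of the compounds shown here, two have been measured in a functional assay on the whole organism (stomach) for inhibition, with Rattus norvegicus as the target, at a dose of 100 mg/kg by the intraduodenal route; on this read-out higher numbers stand for more inhibition at the one dose given (going by the name of the read-out) and lower numbers for less inhibition. Compound 1 gives 10.1% in this assay, and it stands highest of the two numbers; its nearest neighbour is compound 2, which gives -13.4%, a number lower by more than the usual scatter. Going by the values given here, no single-point step between the two measured compounds is available, since they differ in more than one place, so only the two values themselves can be compared.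

Compound 3 `N=C(S)CCCCn1nc(-c2ccccc2)ccc1=O` is not yet measured. It differs from compound 1 in one place: a group of 5 heavy atoms (3 carbon, 1 nitrogen, 1 sulfur; no ring) in place of a group of 2 heavy atoms (1 carbon, 1 nitrogen; no ring), on a saturated chain carbon, two bonds along the chain from an aromatic nitrogen. Nothing measured here shows how such a change affects this assay, so compound 3 is expected to stay close to compound 1, with a step from compound 1 to compound 3 of about a number 2.1 percentage points lower from compound 1 to compound 3 (within the scatter), not clearly beyond the scatter. The estimate for compound 3 in this assay is 8%, within a range from -15% to 35%.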

Compound 3, a percentage reported as inhibition, in the whole organism at one dose (the size of the read-out at that dose, not a potency): 33.8%
The estimate for compound 3 lay 25.8 percentage points below the measured number, within the range that was stated.
By their numbers in this assay, from the lowest: compound 2; then compound 1; then compound 3.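

Putting a group of 5 heavy atoms (3 carbon, 1 nitrogen, 1 sulfur; no ring) in place of cyano, on a saturated chain carbon, two bonds along the chain from an aromatic nitrogen, gives a number 23.7 percentage points higher from compound 1 to compound 3 (beyond the scatter) in this assay. Going by these compounds alone, this is the first single-place step, and it shows that the read-out responds to a change at this position, although one step sets no trend. No measurement is available that accounts for this rise.

The compounds shown leave open whether the added chain length or the sulfur-bearing end of the group goes with the higher number, and how an amine, a carboxylic acid or a longer chain would read at this place. They also give no potency, as each number stands for a single dose.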